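Aryl amine variation on the shared core

The source may report more compounds than this note shows. Statements on the series, on what has been measured and on what is new or still open speak of the compounds shown alone.

Compound 1 `CCCc1ccc(NC2=CC(=O)c3c(nc4n3[C@H]3OC[C@@H](O)[C@H]3OC4)C2=O)cc1`, compound 2 `Cc1ccc(NC2=CC(=O)c3c(nc4n3[C@H]3OC[C@@H](O)[C@H]3OC4)C2=O)cc1` and compound 3 `O=C1C(Nc2ccccc2F)=CC(=O)c2c1nc1n2[C@H]2OC[C@@H](O)[C@H]2OC1` share one core and differ only in the aryl group on the amine nitrogen. In a functional assay on ECa-109 cells for inhibition, with ECa-109 cell line (Homo sapiens) as the target, read by sulforhodamine B assay (a higher number here means a weaker inhibitor, a lower number a stronger inhibitor), compound 1 gives > 4000 nM, a limit of the assay rather than a number. In this assay compound 2 likewise gives > 4000 nM, again a limit. In this assay, among the compounds with values here, compound 3 gives 2660 nM, the only number in the set. Compound 1 and compound 2 both sit at the limit (the limit of > 4000 nM in this assay, at which 2 of the 3 values shown sit). The steps of an at least 1.5-fold lower number from compound 1 to compound 3 (0.17 log units; that floor lies within the scatter) and an at least 1.5-fold lower number from compound 2 to compound 3 (0.17 log units; that floor lies within the scatter) are floors only.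

Compound 4 `O=C1C(Nc2ccc(Br)cc2)=CC(=O)c2c1nc1n2[C@H]2OC[C@@H](O)[C@H]2OC1` differs from compound 3 by 4-bromophenyl in place of 2-fluorophenyl on an amine nitrogen. The steps bearing on this are the two just named, in which 4-propylphenyl and 4-methylphenyl sit at the limit while 2-fluorophenyl gives a number. A 4-bromophenyl resembles those two limit-bound groups more than it does 2-fluorophenyl, so in this assay the expected step is a 1.7-fold higher number from compound 3 to compound 4 (0.23 log units; within the scatter), toward a higher number, with a real chance of a limit. Compound 4 is estimated at 4500 nM, between 2000 nM and 10000 nM.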

Compound 4, half-maximal inhibitory concentration: 1980 nM
Beside the measured number, compound 4's estimate is 2.3-fold (0.36 log units) above it; the whole stated range lies above it.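

In this assay, a measured number is no longer confined to the 2-fluorophenyl group: a 1.3-fold lower number from compound 3 to compound 4 (0.13 log units; within the scatter), so 4-bromophenyl and 2-fluorophenyl on this amine nitrogen are not separated. Among the three compounds with a group on the carbon of the phenyl ring carrying bromo in compound 4, only bromo gives a number, with bromo in place of methyl giving an at least 2.0-fold lower number from compound 2 to compound 4 (0.30 log units; that floor lies within the scatter) and bromo in place of propyl giving an at least 2.0-fold lower number from compound 1 to compound 4 (0.30 log units; that floor lies within the scatter), and both steps are floors only. Compound 1 and compound 2 remain limits of the assay, not numbers: the limit of > 4000 nM in this assay, at which 2 of the 4 values shown sit.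

On these data alone, the true size of those two steps stays unknown. As far as these compounds go, whether a phenyl ring carrying an amine or a carboxylic acid in place of bromo also gives a number remains open.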